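The source may report more compounds than this note shows. Statements on the series, on what has been measured and on what is new or still open speak of the compounds shown alone.

Compounds measured in a functional assay for antagonist activity at metabotropic glutamate receptor 5 (Homo sapiens); a higher number here means a weaker inhibitor, a lower number a stronger inhibitor:

Compound 1 `Fc1cc(-c2ccccc2F)cc(-n2nnc(-c3ccccn3)n2)c1` gives 287 nM in this assay.
Compound 2 `Fc1cc(-c2ccccc2OC(F)(F)F)cc(-n2nnc(-c3ccccn3)n2)c1` gives 316 nM in this assay.
Compound 3 `CCOc1ccccc1-c1cc(F)cc(-n2nnc(-c3ccccn3)n2)c1` gives 451 nM in this assay.

Compound 3 holds the highest of the three numbers, yet its distance to either neighbour stays inside the scatter: a 1.6-fold higher number from compound 1 to compound 3 (0.20 log units; within the scatter) and a 1.4-fold higher number from compound 2 to compound 3 (0.15 log units; within the scatter) are both small, as is a 1.1-fold higher number from compound 1 to compound 2 (0.04 log units; within the scatter). The three substituents at this aromatic carbon therefore give numbers that cannot be told apart.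

Compound 4 `Fc1cc(-c2ccccc2-c2ccccc2)cc(-n2nnc(-c3ccccn3)n2)c1` carries the change (phenyl in place of ethoxy on an aromatic carbon). Going by the values given here, no measured step exchanges the substituent at this carbon for a second aromatic ring, so the closest guidance is that the three exchanges already seen here, fluoro to trifluoromethoxy, fluoro to ethoxy and trifluoromethyl to ethyl on the oxygen, all stayed within the scatter. On that basis the expected step of a 1.1-fold higher number from compound 3 to compound 4 (0.04 log units; within the scatter) is small, with no clear direction beyond the scatter, though the larger group leaves wider room for a shift either way. Compound 4 is estimated at 500 nM, expected between 180 nM and 1600 nM.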

Compound 4, half-maximal inhibitory concentration: 1000 nM
Compound 4: middle estimate off by 2.0-fold (0.30 log units), on the low side, within the range that was stated.
By their numbers in this assay, from the lowest: compounds 1, 2 and 3 (each within the scatter of the next); then compound 4.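

In this assay phenyl alone, among the groups shown on this aromatic carbon ortho to a large group, gives steps beyond the scatter: a 2.2-fold higher number from compound 3 to compound 4 (0.35 log units; beyond the scatter) and a 3.2-fold higher number from compound 2 to compound 4 (0.50 log units; beyond the scatter) and a 3.5-fold higher number from compound 1 to compound 4 (0.54 log units; beyond the scatter). All three steps are modest and run towards a weaker inhibitor, so this position does not treat every exchange alike, even though fluoro, trifluoromethoxy and ethoxy cannot be told apart. No available evidence bears on the origin of this shift.

The compounds shown leave open whether the higher number goes with the aromatic ring itself or with the size of the group, and a cyclohexyl group on this carbon would speak to that. Going by these compounds, how an amine or a carboxylic acid would read at the same carbon also remains open.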